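Series notes: a ring-amine substituent swap at the assay ceiling

The source may report more compounds than this note shows. Statements on the series, on what has been measured and on what is new or still open speak of the compounds shown alone.

Three compounds of the shared core have been run in an assay on isolated protein for inhibition of thyroid hormone receptor beta (Homo sapiens), read by fluorescence polarization; on this read-out lower numbers stand for stronger inhibition and higher numbers for weaker inhibition. Compound 1 `CS(=O)(=O)c1ccc(C(=O)N2CCC(C(=O)N3CCN(c4ccc(F)cc4)CC3)CC2)cc1[N+](=O)[O-]` returns only the limit > 60000 nM, a ceiling of the assay rather than a number. Compound 2 `CN(Cc1ccccc1)C(=O)C1CCN(C(=O)c2ccc(S(C)(=O)=O)c([N+](=O)[O-])c2)CC1` likewise returns the limit > 60000 nM. Compound 3 `Cc1ccc(N2CCN(C(=O)C3CCN(C(=O)c4ccc(S(C)(=O)=O)c([N+](=O)[O-])c4)CC3)CC2)cc1` also returns the limit > 60000 nM, so compound 3 stands at the ceiling together with the other two, and none of the three can be ordered against another. The one single-site step so far, a step that the two limits leave unreadable from compound 1 to compound 3, is therefore not readable in size or direction; all that is shown is the limit of > 60000 nM in this assay, at which 3 of the 3 values shown sit.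

Compound 4 `CN1CCN(C(=O)C2CCN(C(=O)c3ccc(S(C)(=O)=O)c([N+](=O)[O-])c3)CC2)CC1` is the next step from compound 3: methyl in place of 4-methylphenyl on an amine nitrogen in a ring. For the measured compounds named here, no measured step bears on this change, since the only comparison recorded, between compound 1 and compound 3, is itself hidden by two limits, and compound 2 shows that a much smaller amide-side group gives the same ceiling. The expectation is therefore that compound 4 also reaches no readable number, and the step that the limit leaves unreadable from compound 3 to compound 4 is expected to be nothing beyond the scatter. The estimate for compound 4 in this assay is 100000 nM, between 30000 nM and 300000 nM, most likely reported again as a limit only.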

Compound 4, half-maximal inhibitory concentration: > 60000 nM
Compound 4 gave a limit, no number; the forecaster's own chance of this, stated with the estimate: 90%; the middle value is on the limit's open side.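

In this assay compound 4 returns > 60000 nM, a limit and not a number. Its steps from compound 1, compound 2 and compound 3 therefore cannot be read: the limit of > 60000 nM in this assay, at which 4 of the 4 values shown sit.

The compounds shown leave open whether any group on the shared core gives a readable value, and so which change, if any, alters inhibition.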